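The compounds below may be only part of what the source reports. "The series", "measured", "known", "first", "only" and "open" are said of these compounds alone.

Three benzylamides of small amino acids make up the measured set. Compound 1 `CCC[C@@H](N)C(=O)NCc1ccccc1` was tested in a functional assay on the whole organism (strain NMRI) for inhibition, with Mus musculus as the target, in the formalin test, with a stated time of 30 min (a lower number here means that less compound is needed, a higher number that more compound is needed for the effect), and gives 35 mg/kg. Compound 3 `C#CCOCC(N)C(=O)NCc1ccccc1` gives 74 mg/kg in this assay, so compound 1 has the lowest of the two numbers on record, with compound 3 sitting at a higher number that lies beyond the usual scatter of repeated measurements. For compound 2 `NCC(N)C(=O)NCc1ccccc1` the result in this assay is "not determined" (no result reported), so it adds no number to the comparison.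

Compound 4 `CC(C)(C)[C@@H](N)C(=O)NCc1ccccc1` has not yet been measured. It differs from compound 1 in one place: tert-butyl in place of propyl on a saturated chain carbon bound to an amine nitrogen and a carbonyl carbon. Going by the values given here, no pair of measured compounds differing in only one place is available, so no measured step guides the expectation, and the outcome rests on the single number for compound 1 and on the nature of the change.

For compound 4 in this assay a value of about 45 mg/kg is expected, between 20 mg/kg and 110 mg/kg. This estimate means a step of a 1.3-fold higher number from compound 1 to compound 4 (0.11 log units; within the scatter) that is expected to stay within, or only slightly beyond, the usual scatter.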

Compound 4, dose for half-maximal effect: > 22 mg/kg
Compound 4 ended at the assay's limit (the forecaster's own chance of this, stated with the estimate: 10%); the middle value does not contradict the limit.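

In this assay compound 4 gives > 22 mg/kg, which is a limit of the assay and not a number. Going by these compounds alone, no step from compound 1 to compound 4 can be read from it. The compounds shown leave open whether tert-butyl in place of propyl changes the number in this assay, and in which direction.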